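A 4-bromophenyl in place of 3-chlorophenyl

This account rests on a few compounds, and the source may have more. Where it says the series, first, only, none or still open, it means among the compounds named here.

In a functional assay on MOLT-4 cells (Homo sapiens) for inhibition, read by MTT assay, with a stated time of 72 h (on this read-out lower numbers stand for stronger inhibition and higher numbers for weaker inhibition), compound 1 (`COc1cc(NC(C)CCCNC(=O)Nc2cccc(F)c2)c2ncccc2c1`) gives 23000 nM and compound 2 (`COc1cc(NC(C)CCCNC(=O)Nc2cccc(Cl)c2)c2ncccc2c1`) gives 21000 nM as its reading. These two numbers lie within the scatter of each other, so compound 2 stands level with compound 1 and no order can be drawn between them. Compound 3 (`COc1cc(NC(C)CCCNC(=O)Nc2ccc(Br)cc2)c2ncccc2c1`) is still unmeasured. It carries 4-bromophenyl in place of 3-chlorophenyl on an amide-type nitrogen. Among the measured compounds shown here, the one measured step that bears on this is chloro in place of fluoro on an aromatic carbon (a 1.1-fold lower number from compound 1 to compound 2 (0.04 log units; within the scatter)), which stays within the scatter. For the measured compounds named here, no measured compound carries 4-bromophenyl, so the evidence is thin. No step beyond the scatter is therefore expected in this assay in either direction, and the estimated change (a 1.1-fold lower number from compound 2 to compound 3 (0.02 log units; within the scatter)) is small. For compound 3 the expected value is 20000 nM (range 9000 nM to 45000 nM) on this evidence.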

Compound 3, half-maximal inhibitory concentration: 25000 nM
For compound 3 the middle estimate is 1.3-fold (0.10 log units) below the measured one; low and high end bracket the measured number.
By their numbers in this assay, from the lowest: compounds 2, 1 and 3 (each within the scatter of the next).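

Replacing the ring on the amide-type nitrogen leaves the reading in this assay level, whether 4-bromophenyl replaces 3-chlorophenyl (a 1.2-fold higher number from compound 2 to compound 3 (0.08 log units; within the scatter)) or 3-fluorophenyl (a 1.1-fold higher number from compound 1 to compound 3 (0.04 log units; within the scatter)). The earlier pair changed only the halogen, with the ring numbering the same in both names, whereas these steps change both the halogen and the number in the group's name, and still neither step leaves the scatter. Nothing measured here offers a reason for this flat picture.

As far as these compounds go, all three compounds carry a single halogen on this phenyl ring, so it remains open whether an amine or a carboxylic acid on that ring would shift the number beyond the scatter. From the compounds shown here alone, it also remains open whether a longer chain joining the shared core to this end of the molecule would do so.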